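The source may report more compounds than this note shows. Statements on the series, on what has been measured and on what is new or still open speak of the compounds shown alone.

Three compounds share one core and differ only in the aryl group attached to an aromatic nitrogen. In a functional assay on HCT-116 cells (Homo sapiens) for antiproliferative activity, read by MTT assay, with a stated time of 48 h (on this read-out lower numbers stand for stronger inhibition and higher numbers for weaker inhibition), compound 1 `COc1ccc(-n2cc(COc3ccc(/C=C/C(C)=O)cc3OC)nn2)cc1` gives 21300 nM, compound 2 `COc1cc(/C=C/C(C)=O)ccc1OCc1cn(-c2c(Cl)cccc2Cl)nn1` gives 2000 nM, and compound 3 `COc1cc(/C=C/C(C)=O)ccc1OCc1cn(-c2ccc([N+](=O)[O-])cc2)nn1` gives 96300 nM. Compound 3 therefore stands with the highest number of the three: there was a 4.5-fold higher number from compound 1 to compound 3 (0.66 log units; beyond the scatter) and a 48-fold higher number from compound 2 to compound 3 (1.68 log units; beyond the scatter). Compound 4 `COc1cc(/C=C/C(C)=O)ccc1OCc1cn(-c2ccc(-c3ccccc3)cc2)nn1` differs from compound 3 by phenyl in place of nitro on an aromatic carbon. Going by the values given here, the one measured step that touches this spot, a 4.5-fold higher number from compound 1 to compound 3 (0.66 log units; beyond the scatter), saw the number rise when nitro entered, so taking nitro out again is expected to bring the number down, by roughly a 6.4-fold lower number from compound 3 to compound 4 (0.81 log units; beyond the scatter), although no measured compound carries a phenyl there. Compound 4 is accordingly estimated at 15000 nM, within a range from 3000 nM to 70000 nM.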

Compound 4, half-maximal inhibitory concentration: 65300 nM
The estimate for compound 4 lay 4.4-fold (0.64 log units) below the measured number, within the range that was stated.
By their numbers in this assay, from the lowest: compound 2; then compound 1; then compounds 4 and 3 (each within the scatter of the next).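

Replacing nitro with phenyl at this position gives a 1.5-fold lower number from compound 3 to compound 4 (0.17 log units; within the scatter) in this assay, so adding a whole aromatic ring leaves the read-out about where nitro put it. Phenyl also gives a 3.1-fold higher number from compound 1 to compound 4 (0.49 log units; beyond the scatter), which places compound 1, with its methoxy, clear of both compound 3 and compound 4 at this position. No measured evidence accounts for these results. The compounds shown leave open how an amine, a carboxylic acid or a longer chain at this position would compare, and whether the same holds on another core.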